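Fluoro to Nitro on a Weak Cell-Growth Inhibitor

This account rests on a few compounds, and the source may have more. Where it says the series, first, only, none or still open, it means among the compounds named here.

Within the data shown here, compound 1 `O=C(O)C1=Cc2ccccc2OC1(OCc1cc(-c2ccc(F)cc2)no1)C(F)(F)F` is the only compound here with a plain number. In a functional assay on MCF7 cells (Homo sapiens) for inhibition, read by MTT assay, with a stated time of 24 h (a higher number here means a weaker inhibitor, a lower number a stronger inhibitor), compound 1 gives 64200 nM, a weak result. Compound 2 `CCOC(=O)C1=Cc2ccccc2OC1(OCc1cn(CC(=O)Nc2ccc(C)cc2)nn1)C(F)(F)F` is the other compound measured. In this assay compound 2 reaches only the limit of the measurement, > 150000 nM, which is not a number but a boundary; as the limit of > 150000 nM in this assay, at which 1 of the 2 values shown sits, records, one of the two values shown is such a limit.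

Compound 3 `O=C(O)C1=Cc2ccccc2OC1(OCc1cc(-c2ccc([N+](=O)[O-])cc2)no1)C(F)(F)F` differs from compound 1 in one place: nitro in place of fluoro on an aromatic carbon. Among the measured compounds shown here, no measured pair here changes in this way, so there is no measured step to lean on. The change from compound 1 to compound 3 is expected to stay within the usual scatter, a 1.2-fold lower number from compound 1 to compound 3 (0.07 log units; within the scatter), with no clear direction. Compound 3 is therefore estimated to give about 55000 nM in this assay, somewhere between 15000 nM and 150000 nM.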

Compound 3, half-maximal inhibitory concentration: > 150000 nM
Compound 3 was reported as a limit; the forecaster's own chance of this, stated with the estimate: 25%; middle value at least 2.7-fold (0.43 log units) away from the limit.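

Nitro in place of fluoro gives the first measured step in this set, an at least 2.3-fold higher number from compound 1 to compound 3 (0.36 log units; beyond the scatter), so the group at this spot on the ring, para to a large group, does affect the reading in this assay. For compound 3, > 150000 nM is a limit of the assay and not a number. The step therefore fixes a direction, towards a weaker inhibitor, but not a full size, because its reading ends at a boundary: the limit of > 150000 nM in this assay, at which 2 of the 3 values shown sit.

With only fluoro and nitro shown at this position, it remains open whether fluoro is better than most groups here or nitro is unusually poor. An amine, a methoxy group or a plain hydrogen in the same place would help to separate these two readings.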